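This account rests on a few compounds, and the source may have more. Where it says the series, first, only, none or still open, it means among the compounds named here.

Compound 2, with the structure `COc1cc(/C=C/C(=O)/C=C/c2cc(OC)c(OC)c(OC)c2)ccc1OCc1cn(CCCOc2cc(=O)oc3ccccc23)nn1`, and compound 1, with the structure `COc1ccccc1/C=C/C(=O)/C=C/c1ccc(OCc2cn(CCOc3cc(=O)oc4ccccc34)nn2)c(OC)c1`, were both tested in a functional assay on HCT-116 cells (Homo sapiens) for cytotoxicity, read by sulforhodamine B assay, with a stated time of 48 h; on this read-out lower numbers stand for stronger inhibition and higher numbers for weaker inhibition. Compound 1 gives 9490 nM, and compound 2 gives 8650 nM. The two numbers sit within the usual scatter of one another, so neither compound can be told apart from the other on this read-out. The account then turns to compound 3, whose structure is `COc1ccc(/C=C/C(=O)/C=C/c2ccc(OCc3cn(CCCOc4cc(=O)oc5ccccc45)nn3)c(OC)c2)cc1OC`. Compound 3 differs from compound 2 in one place: hydrogen in place of methoxy on an aromatic carbon. For the measured compounds named here, no measured pair shows what this change does. Since compound 2 gives 8650 nM and compound 1 gives 9490 nM despite their different substitution, the expected step from compound 2 to compound 3 is a 1.0-fold higher number from compound 2 to compound 3 (0.02 log units; within the scatter), none beyond the scatter. Compound 3 is therefore estimated at 9000 nM, with a range from 4000 nM to 20000 nM.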

Compound 3, half-maximal inhibitory concentration: 11000 nM
The estimate for compound 3 lay 1.2-fold (0.09 log units) below the measured number; measured number inside the range.
By their numbers in this assay, from the lowest: compounds 2, 1 and 3 (each within the scatter of the next).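

For the compounds shown here, compounds 2 and 3 give the first direct reading of this change: replacing methoxy with hydrogen, which turns 3,4,5-trimethoxyphenyl into 3,4-dimethoxyphenyl, gives in this assay a 1.3-fold higher number from compound 2 to compound 3 (0.10 log units; within the scatter). On this read-out, then, this methoxy group can be exchanged for hydrogen on this core without a difference that can be told from the scatter, although this single pair says nothing about other cores. No measurement available here accounts for this result.

From the compounds shown here alone, whether an amine or a carboxylic acid on this aromatic carbon would move the number remains open. So does whether the same exchange would read alike on a compound with a longer chain between the triazole and the oxygen of the far end.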